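Swapping 4-chlorophenyl for 3-aminophenyl on the shared core

The compounds below may be only part of what the source reports. "The series", "measured", "known", "first", "only" and "open" are said of these compounds alone.

In a functional assay on the whole organism with Mus musculus as the target (on this read-out higher numbers stand for an effect only at larger amounts of compound and lower numbers for an effect already at smaller amounts), the shared core has been measured with three different groups. Compound 1 `COc1cc2c(cc1OC)C(c1ccc(Br)cc1)=NNC(=O)C2` gives 82.5 umol/kg as its number, compound 2 `COc1cc2c(cc1OC)C(c1ccccc1)=NNC(=O)C2` gives 31.8 umol/kg as its number, and compound 3 `COc1cc2c(cc1OC)C(c1ccc(Cl)cc1)=NNC(=O)C2` gives 75.3 umol/kg as its number. Compound 3 holds the second highest of the three numbers, yet chloro in place of bromo gives only a 1.1-fold lower number from compound 1 to compound 3 (0.04 log units; within the scatter) and so separates nothing. The hydrogen compound stands apart in both remaining comparisons, with a 2.6-fold lower number from compound 1 to compound 2 (0.41 log units; beyond the scatter) on one side and a 2.4-fold higher number from compound 2 to compound 3 (0.37 log units; beyond the scatter) on the other, both modest in size.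

For the measured compounds named here, the next compound is compound 4 `COc1cc2c(cc1OC)C(c1cccc(N)c1)=NNC(=O)C2`, in which 3-aminophenyl stands in place of 4-chlorophenyl on a carbon with a double bond to nitrogen 3-aminophenyl in place of 4-chlorophenyl on a carbon with a double bond to nitrogen as the only change. Going by the values given here, no measured compound carries an amino group, so the data say nothing direct about it. Only the loss of the chloro has a guide, the modest step between the chloro and hydrogen compounds. A step towards a lower number is therefore expected, no larger than those modest steps. The expected move is a 1.9-fold lower number from compound 3 to compound 4 (0.27 log units; within the scatter) on this reasoning. For compound 4 the estimate is 40 umol/kg as the middle value, with an expected range from 14 umol/kg to 110 umol/kg in this assay once it is measured.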

Compound 4, dose for half-maximal effect: 18.3 umol/kg
Beside the measured number, compound 4's estimate is 2.2-fold (0.34 log units) above it, and the stated range covers the measured number.
By their numbers in this assay, from the lowest: compounds 4 and 2 (each within the scatter of the next); then compounds 3 and 1 (each within the scatter of the next).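

In this assay, 3-aminophenyl differs clearly from both halogenated rings: a 4.1-fold lower number from compound 3 to compound 4 (0.61 log units; beyond the scatter) is matched by a 4.5-fold lower number from compound 1 to compound 4 (0.65 log units; beyond the scatter) on the bromo side, and both steps lie beyond the scatter. Against the plain phenyl ring, however, a 1.7-fold lower number from compound 2 to compound 4 (0.24 log units; within the scatter) does not separate the two compounds, so at this carbon with a double bond to nitrogen the amino group leaves the number in the same range as hydrogen, and compound 2 and compound 4 together stand apart from the two halogen compounds, compound 1 and compound 3. No measurement is available that would explain this grouping of the four compounds.

Because compound 4 differs from compound 3 in both the group and its place on the ring, these compounds cannot show whether the amino group's identity or its location matters, and a phenyl ring carrying the amino group where compound 3 carries its chloro would separate the two. Going by these compounds, it also remains open whether a hydroxy or a dimethylamino group at the amino group's place would stay in this range.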